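Replacing Benzyloxy in Compound 3

The source may report more compounds than this note shows. Statements on the series, on what has been measured and on what is new or still open speak of the compounds shown alone.

In an ADME assay on cells (Fibroblast) for cytotoxicity (a higher number here means a weaker inhibitor, a lower number a stronger inhibitor), compound 3 `O=C(CCCCC[C@H](NC(=O)OCc1ccccc1)C(=O)Nc1ccc(-c2ccccc2)cc1)NO` gives 2200 nM. For the measured compounds named here, compound 2 `CN(C)c1ccc(C(=O)N[C@@H](CSCCCC(=O)NO)C(=O)NC2CCCc3ccccc32)cc1` gives the same number, 2200 nM, and the two together stand highest of the three measured so far. Compound 1 `CN(C)c1ccc(NC(=O)[C@H](CSCCCC(=O)NO)NC(=O)c2ccc(N(C)C)cc2)cc1` gives 600 nM, clearly lower than both.

Compound 4 `O=C(CCCCC[C@H](NC(=O)c1ccc(Br)cc1)C(=O)Nc1ccc(-c2ccccc2)cc1)NO` differs from compound 3 in one place: 4-bromophenyl in place of benzyloxy on a carbonyl carbon. In words, 4-bromophenyl stands in place of benzyloxy on a carbonyl carbon, and the carbonyl's other neighbour, an amide-type nitrogen, stays.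

Going by the values given here, only one measured step bears on this, and only loosely: a 3.7-fold higher number from compound 1 to compound 2 (0.56 log units; beyond the scatter). It is modest but beyond the scatter. However, it changes a group on an amide-type nitrogen rather than on a carbonyl carbon, and on a different core from that of compound 3. Among the compounds with values here, no measured pair tests the new change directly, so no direction can be argued and no shift beyond the scatter is expected.

The expected change is a 1.1-fold lower number from compound 3 to compound 4 (0.04 log units; within the scatter). For compound 4 the estimated value is 2000 nM, with an expected range from 700 nM to 5500 nM.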

Compound 4, half-maximal inhibitory concentration: 190 nM
The estimate for compound 4 lay 11-fold (1.02 log units) above the measured number; measured number below the stated range.
By their numbers in this assay, from the lowest: compound 4; then compound 1; then compounds 2 and 3 (each within the scatter of the next).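

Putting 4-bromophenyl in place of benzyloxy on this carbonyl carbon gives a 12-fold lower number from compound 3 to compound 4 (1.06 log units; beyond the scatter) in this assay, so the group at this place, where the carbonyl's other neighbour is an amide-type nitrogen, can move the number by a large step on the core that compound 3 and compound 4 share. For the compounds shown here, the only earlier step, a 3.7-fold higher number from compound 1 to compound 2 (0.56 log units; beyond the scatter), was modest, lay on an amide-type nitrogen and sat on a different core, so it said nothing about this place. Nothing available explains why the step is so large.

Going by these compounds, whether the bromine or the loss of the benzyloxy oxygen matters more stays open, and plain phenyl or benzyl on the same carbonyl carbon would help to separate the two. On these data alone, whether the same exchange would act alike on the core of compound 1 also remains unknown.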